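Hydroxymethyl to 1-hydroxyethyl: first notes on the series

This account rests on a few compounds, and the source may have more. Where it says the series, first, only, none or still open, it means among the compounds named here.

Two entries exist so far, compound 1 (`CC(=O)Nc1nc(C)c(-c2nc(CC(F)(F)F)no2)s1`) and compound 2 (`CC(=O)Nc1nc(C)c(-c2nc(CC(C)(C)CO)no2)s1`). In an ADME assay on cells (Hepatocyte, Rattus norvegicus) for metabolic stability, read by LC-MS, with a stated time of 1 h, tested at 5 uM (on this read-out lower numbers stand for a less stable compound and higher numbers for a more stable compound), the entry for compound 1 reads "not determined" (no result reported) and offers no comparison. For the measured compounds named here, compound 2 stands at 11.3% as the only number available, so its rank cannot be judged. Compound 3 (`CC(=O)Nc1nc(C)c(-c2nc(CC(C)(C)C(C)O)no2)s1`) differs from compound 2 at one place, where hydroxymethyl becomes 1-hydroxyethyl: methyl in place of hydrogen on a saturated chain carbon bound to an oxygen on a saturated carbon and a saturated chain carbon is the whole change. Going by the values given here, no measured pair shows what such a change does in this assay, so the expectation is weakly founded. It starts from compound 2 at 11.3% and allows only a small upward move, probably within the usual scatter. The estimated step of a number 3.7 percentage points higher from compound 2 to compound 3 (within the scatter) is therefore modest. For compound 3 the estimate is 15% as the expected value, with 5% to 35% as its expected range.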

Compound 3, percent of the compound remaining: 20.9%
Beside the measured number, compound 3's estimate is 5.9 percentage points below it; the measured number falls inside the stated range.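

In this assay the first measured pair gives a number 9.6 percentage points higher from compound 2 to compound 3 (within the scatter) and so does not separate the two compounds beyond repeat measurements. Methyl in place of hydrogen on this saturated chain carbon bound to an oxygen therefore has no readable effect here, and this single pair supports no rule for the series beyond compound 2 and compound 3. Nothing on hand gives an explanation for this reading.

From the compounds shown here alone, whether an ethyl group or a longer chain on the same saturated chain carbon, or an amine or a carboxylic acid in place of the hydroxyl, would give a step beyond the scatter remains open. For the compounds shown here, the entry for compound 1 still allows no comparison with either compound.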